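Pyrazolyl ureas: thermal shift notes, phenyl to tert-butyl

The source may hold more compounds than are shown below. What is called first, only, known or untested is meant among the compounds shown, and "the series" means these compounds.

Measured so far:
compound 1, `Cc1ccccc1NC(=O)Nc1cc(C(C)(C)C)nn1-c1ccccc1`, 8.6 degrees C
compound 2, `CC(C)(C)c1cc(NC(=O)Nc2ccc(F)cc2)n(-c2ccccc2)n1`, 6.5 degrees C
compound 3, `CC(C)(C)c1cc(NC(=O)Nc2cc(F)cc(F)c2)n(-c2ccccc2)n1`, 2.5 degrees C

In an assay on isolated protein for inhibition of serine/threonine-protein kinase 10 (Homo sapiens), read by thermal shift assay, tested at 10 uM (a lower number here means that the compound stabilises the target less, a higher number that the compound stabilises the target more against heat), compound 3 gives 2.5 degrees C and stands lowest of the three numbers. Its nearest neighbour is compound 2, whose value in this assay is 6.5 degrees C; the gap is a number 4.0 degrees C lower from compound 2 to compound 3 (beyond the scatter). The furthest is compound 1, and the step is a number 6.1 degrees C lower from compound 1 to compound 3 (beyond the scatter). The remaining step, a number 2.1 degrees C lower from compound 1 to compound 2 (beyond the scatter), also concerns the aryl group on the amide-type nitrogen.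

Compound 4, `CC(C)(C)c1cc(NC(=O)Nc2cc(F)cc(F)c2)n(C(C)(C)C)n1`, is not yet measured. The change from compound 3 is tert-butyl in place of phenyl on an aromatic nitrogen. All three measured steps alter the aryl on the amide-type nitrogen and leave the group on the aromatic nitrogen untouched, so none of them bears directly on this change. For the measured compounds named here, there is no measured step on this position, and therefore no basis for expecting a step in either direction beyond the scatter; the uncertainty is correspondingly wide.

For compound 4 the expected value in this assay is 2.5 degrees C, with a range from -0.5 degrees C to 5.5 degrees C. The expected step is no change at the digits printed from compound 3 to compound 4 (within the scatter).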

Compound 4, shift of the target's melting temperature: -0.2 degrees C
For compound 4 the middle estimate is 2.7 degrees C above the measured one, and the stated range covers the measured number.
By their numbers in this assay, from the lowest: compound 4; then compound 3; then compound 2; then compound 1.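

In this assay, for the compounds shown here, the group on the aromatic nitrogen proves able to move the read-out on its own: with 3,5-difluorophenyl held on the amide-type nitrogen, tert-butyl in place of phenyl gives a number 2.7 degrees C lower from compound 3 to compound 4 (beyond the scatter) and this is the first step read at this position. Until now every step lay on the aryl of the amide-type nitrogen, so the series showed only that this aryl matters, and it now has a second position that responds, with compound 4 at -0.2 degrees C in the same assay. Nothing available here accounts for this step, whether through the loss of the six-membered aromatic ring or through the change from phenyl to tert-butyl as such.

Still open, going by these compounds, is whether a step of this direction and size would recur with 2-methylphenyl or 4-fluorophenyl on the amide-type nitrogen, as tert-butyl on the aromatic nitrogen appears here only with 3,5-difluorophenyl. Also open, on these data alone, is how a small methyl group or a pyridyl ring would stand on the aromatic nitrogen relative to phenyl and tert-butyl.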